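Triazolyl for fluoropyridyl on the biaryl tail

The compounds below may be only part of what the source reports. "The series", "measured", "known", "first", "only" and "open" are said of these compounds alone.

Measured compounds in an in vitro assay on CHO cells for displacement of a labelled ligand from Bombesin receptor subtype-3 (Homo sapiens), read by scintillation counting, with a stated time of 2 h; a lower number here means a stronger inhibitor, a higher number a weaker inhibitor:
compound 1 `CCC(C)(C)Cc1c[nH]c(CCc2ccc(-c3ccncc3)cc2)n1` gives 101 nM
compound 2 `CCC(C)(C)Cc1c[nH]c(CCc2ccc(-n3ccnn3)cc2)n1` gives 390 nM
compound 3 `CCC(C)(C)Cc1c[nH]c(CCc2ccc(-c3ccc(F)cn3)cc2)n1` gives 19 nM

Compound 3 holds the lowest number of the three. The two steps that reach it, a 5.3-fold lower number from compound 1 to compound 3 (0.73 log units; beyond the scatter) and a 21-fold lower number from compound 2 to compound 3 (1.31 log units; beyond the scatter), both lie beyond the scatter, so compound 3 is the strongest inhibitor among the measured compounds in this assay.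

Compound 4 `CCC(C)(C)Cc1c[nH]c(CCc2ccc(-n3cncn3)cc2)n1` differs from compound 3 in one place: 1H-1,2,4-triazol-1-yl in place of 5-fluoropyridin-2-yl on an aromatic carbon. The change sits on an aromatic carbon of a six-membered aromatic ring of carbon only, para to a large group.

Going by the values given here, two measured steps bear on it. The step from compound 1 to compound 2 a 3.9-fold higher number from compound 1 to compound 2 (0.59 log units; beyond the scatter) shows that a triazol-1-yl in place of a six-membered azine ring weakens binding, and the step from compound 2 to compound 3 a 21-fold lower number from compound 2 to compound 3 (1.31 log units; beyond the scatter) shows the same direction in reverse and at large size. Compound 4 carries a 1H-1,2,4-triazol-1-yl, which counts the same way as the 1H-1,2,3-triazol-1-yl of compound 2, so a large rise in this assay is expected, putting compound 4 near compound 2.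

For compound 4 the expected value is 300 nM, with a range of 90 nM to 1000 nM, an estimated step of a 16-fold higher number from compound 3 to compound 4 (1.20 log units; beyond the scatter).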

Compound 4, half-maximal inhibitory concentration: 340 nM
Compound 4: the middle estimate sits 1.1-fold (0.05 log units) below what was measured, and the stated range covers the measured number.
By their numbers in this assay, from the lowest: compound 3; then compound 1; then compounds 4 and 2 (each within the scatter of the next).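

In this assay the arrangement of the triazole nitrogens does not separate the two triazolyl compounds: a 1.1-fold lower number from compound 2 to compound 4 (0.06 log units; within the scatter). Going by these compounds alone, the loss seen with the first triazolyl group therefore recurs with a second one, at an 18-fold higher number from compound 3 to compound 4 (1.25 log units; beyond the scatter) against 5-fluoropyridin-2-yl and at a 3.4-fold higher number from compound 1 to compound 4 (0.53 log units; beyond the scatter) against pyridin-4-yl, so among the four compounds both triazolyl groups stand weaker than both pyridyl groups, with no compound going against this. The data at hand contain no measurement that explains the gap between the triazolyl and pyridyl groups.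

The compounds shown cover only pyridyl and triazolyl groups at this place, so it remains open how much of the advantage of compound 3 over compound 1 belongs to the fluorine and how much to the point of attachment of the pyridine ring, a question that an unsubstituted pyridin-2-yl group would address. Also open, as far as these compounds go, is how this place responds to a plain phenyl ring, an amine or a carboxylic acid.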